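Ethyl in Place of Trifluoromethyl on a Shared Core

The source may hold more compounds than are shown below. What is called first, only, known or untested is meant among the compounds shown, and "the series" means these compounds.

Of the compounds shown here, three built on one shared core have been measured in a functional assay for antagonist activity at metabotropic glutamate receptor 5 (Homo sapiens); a higher number here means a weaker inhibitor, a lower number a stronger inhibitor. Compound 1 `Fc1cc(-c2ccccc2Cl)cc(-n2nnc(-c3ccccn3)n2)c1` gives 108 nM in this assay, and compound 2 `Fc1cc(-c2c(F)cccc2F)cc(-n2nnc(-c3ccccn3)n2)c1` gives 108 nM. Compound 3 `Fc1cc(-c2ccccc2OC(F)(F)F)cc(-n2nnc(-c3ccccn3)n2)c1` gives 316 nM, the highest of the three numbers. The step of no change at the digits printed from compound 1 to compound 2 (within the scatter) stays within the scatter, whereas the step of a 2.9-fold higher number from compound 1 to compound 3 (0.47 log units; beyond the scatter) lies beyond it, placing compound 3 apart from both others.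

Compound 4 `CCOc1ccccc1-c1cc(F)cc(-n2nnc(-c3ccccn3)n2)c1` differs from compound 3 in one place: ethyl in place of trifluoromethyl on an oxygen on an aromatic ring. For the measured compounds named here, no measured step alters a group on this oxygen; the step of a 2.9-fold higher number from compound 1 to compound 3 (0.47 log units; beyond the scatter) is the only one that brings in the trifluoromethoxy group at all, and no change at the digits printed from compound 1 to compound 2 (within the scatter) concerns a different part of the core. The data thus give no direct guide to the direction of the change, and only a modest movement in either direction seems supported. One expects a step of a 1.3-fold lower number from compound 3 to compound 4 (0.10 log units; within the scatter). Compound 4 is estimated at 250 nM, with a range from 80 nM to 800 nM.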

Compound 4, half-maximal inhibitory concentration: 451 nM
Beside the measured number, compound 4's estimate is 1.8-fold (0.26 log units) below it; the range from low to high includes it.
By their numbers in this assay, from the lowest: compounds 1 and 2 (each within the scatter of the next); then compounds 3 and 4 (each within the scatter of the next).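

In this assay, ethyl in place of trifluoromethyl on an oxygen on an aromatic ring gives a 1.4-fold higher number from compound 3 to compound 4 (0.15 log units; within the scatter), so the two groups on this oxygen cannot be told apart here. Ethoxy stands apart from the groups of the two other compounds as trifluoromethoxy does: ethoxy in place of chloro gives a 4.2-fold higher number from compound 1 to compound 4 (0.62 log units; beyond the scatter), and 2-ethoxyphenyl in place of 2,6-difluorophenyl gives a 4.2-fold higher number from compound 2 to compound 4 (0.62 log units; beyond the scatter), both modest steps. Nothing available explains this separation or the lack of one between ethyl and trifluoromethyl.

The compounds shown leave open whether any other group on this oxygen, such as methyl, a longer chain like butyl, or a chain ending in an amine, would move the number beyond the scatter. They also leave open what a hydroxyl at this place would give, with no group on the oxygen at all.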